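This account rests on a few compounds, and the source may have more. Where it says the series, first, only, none or still open, it means among the compounds named here.

Of the compounds shown here, three have been measured in a physicochemical assay for solubility (a lower number here means a less soluble compound, a higher number a more soluble compound), and each returns only a limit, not a number. Compound 1 (`CNC(=O)c1cc(C(=O)NC2CC2)cn(Cc2ccc(F)cc2)c1=O`) gives >= 162 ug/mL, which is a limit. Compound 2 (`CNC(=O)c1cc(C(=O)NC2CCOCC2)cn(Cc2ccccc2)c1=O`) gives >= 174 ug/mL, also a limit. Compound 3 (`CNC(=O)c1cc(C(=O)NC2CCC2)cn(Cc2ccccn2)c1=O`) gives >= 103 ug/mL, again a limit. Compound 1 therefore stands on a limit, with no exact number as a starting point. Compound 4 (`CNC(=O)c1cc(C(=O)NC2CC2)cn(Cc2cccc([C@@H](C)O)c2)c1=O`) carries 3-(1-hydroxyethyl)phenyl in place of 4-fluorophenyl on a saturated chain carbon bound to an aromatic nitrogen. Among the measured compounds shown here, no measured step tests this change. The expected step that the limit leaves unreadable from compound 1 to compound 4 is estimated to stay within the scatter, with no firm direction. Compound 4 is expected at 170 ug/mL, with an estimated range of 105 ug/mL to 230 ug/mL.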

Compound 4, solubility: >= 131 ug/mL
Compound 4 gave a limit, no number (the forecaster's own chance of this, stated with the estimate: 70%); the middle value lies beyond the limit too.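

Compound 1 and compound 4 both return only limits in this assay, and the step between them cannot be read. Going by these compounds, whether 3-(1-hydroxyethyl)phenyl in place of 4-fluorophenyl shifts the read-out at all remains open.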